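This account rests on a few compounds, and the source may have more. Where it says the series, first, only, none or still open, it means among the compounds named here.

Measured in an assay on HEK293 cells for antagonist activity at P2X purinoceptor 7 (Homo sapiens), read by fluorescence, with a stated time of 2 h; on this read-out lower numbers stand for stronger inhibition and higher numbers for weaker inhibition:
compound 1 `O=C(c1ccc(Cl)c(C(F)(F)F)c1)N1CCC(n2cncc2-c2ccc(OS(=O)(=O)c3ccccc3)cc2)CC1` gives 702 nM
compound 2 `O=C(c1ccc(Cl)c(C(F)(F)F)c1)N1CCC(n2cncc2-c2ccc(OS(=O)(=O)c3cccc(Br)c3)cc2)CC1` gives 896 nM
compound 3 `O=C(c1ccc(Cl)c(C(F)(F)F)c1)N1CCC(n2cncc2-c2ccc(OS(=O)(=O)c3cccc([N+](=O)[O-])c3)cc2)CC1` gives 249 nM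

Among these three numbers compound 1 stands second highest in this assay; compound 2 is within the scatter of it a 1.3-fold higher number from compound 1 to compound 2 (0.11 log units; within the scatter), and compound 3 sits beyond the scatter, a modest step of a 2.8-fold lower number from compound 1 to compound 3 (0.45 log units; beyond the scatter). Compound 4 `O=C(NC1CC1)c1cccc(S(=O)(=O)Oc2ccc(-c3cncn3C3CCN(C(=O)c4ccc(Cl)c(C(F)(F)F)c4)CC3)cc2)c1` differs from compound 1 by cyclopropylcarbamoyl in place of hydrogen on an aromatic carbon. Both measured steps at this position bear on the change: replacing hydrogen by bromo did nothing beyond the scatter, while replacing hydrogen by nitro lowered the number modestly; the step from compound 2 to compound 3 a 3.6-fold lower number from compound 2 to compound 3 (0.56 log units; beyond the scatter) points the same way. Substitution here has so far been neutral or mildly helpful, and a similar, small step is expected for compound 4 a 1.4-fold lower number from compound 1 to compound 4 (0.15 log units; within the scatter). Compound 4 is therefore estimated at 500 nM in this assay, with a range from 180 nM to 1400 nM.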

Compound 4, half-maximal inhibitory concentration: 88 nM
Beside the measured number, compound 4's estimate is 5.7-fold (0.75 log units) above it; measured number below the stated range.
By their numbers in this assay, from the lowest: compound 4; then compound 3; then compounds 1 and 2 (each within the scatter of the next).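

In this assay, the change from phenyl to 3-(cyclopropylcarbamoyl)phenyl gives a larger gain than any earlier substitution at this position (an 8.0-fold lower number from compound 1 to compound 4 (0.90 log units; beyond the scatter)), and it also improves on nitro (a 2.8-fold lower number from compound 3 to compound 4 (0.45 log units; beyond the scatter)) and on bromo (a 10-fold lower number from compound 2 to compound 4 (1.01 log units; beyond the scatter)). Compound 4 therefore holds the lowest number of the four, showing that this position accepts a much larger substituent than bromo or nitro. No measured data here explain the gain.

As far as these compounds go, it remains open whether the gain needs the cyclopropyl ring or only the amide. A primary amide, a methyl amide or a carboxylic acid at this position would help separate these.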